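Chloroacetanilides: chain homologation from compound 2

The source may hold more compounds than are shown below. What is called first, only, known or untested is meant among the compounds shown, and "the series" means these compounds.

Measured so far:
compound 1, `O=C(CCl)Nc1ccc(I)cc1`: 9700 nM
compound 2, `CC(C)(C)c1ccc(NC(=O)CCl)cc1`: 15000 nM

In a functional assay on HT-29 cells (Homo sapiens) for antiproliferative activity, with a stated time of 48 h (on this read-out lower numbers stand for stronger inhibition and higher numbers for weaker inhibition), compound 1 gives 9700 nM; compound 2 gives 15000 nM. Going by the values given here, the single step, a 1.5-fold higher number from compound 1 to compound 2 (0.19 log units; within the scatter), replaces iodo with tert-butyl on the aromatic carbon and stays within the scatter, so compound 2 and compound 1 cannot be told apart on these numbers; compound 2 is simply one of two near-equal values.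

Compound 3, `CC(C)(C)c1ccc(NC(=O)CCCl)cc1`, differs from compound 2 by chloromethyl in place of chloro on a saturated chain carbon bound to a carbonyl carbon. Among the compounds with values here, no measured step touches this chain; the only step on record concerns an aromatic substituent and gives no guidance on lengthening the chain between the chloro group and the carbonyl. The expectation therefore rests on the value of compound 2 alone, with a wide band and a lean towards a higher number. The step from compound 2 to compound 3 is estimated as a 2.0-fold higher number from compound 2 to compound 3 (0.30 log units; within the scatter). Compound 3 is estimated at 30000 nM, between 10000 nM and 100000 nM.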

Compound 3, half-maximal inhibitory concentration: 88000 nM
Compound 3: middle estimate off by 2.9-fold (0.47 log units), on the low side, within the range that was stated.
By their numbers in this assay, from the lowest: compounds 1 and 2 (each within the scatter of the next); then compound 3.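

In this assay, replacing chloromethyl with 2-chloroethyl at the saturated chain carbon bound to a carbonyl carbon gives a 5.9-fold higher number from compound 2 to compound 3 (0.77 log units; beyond the scatter). Going by these compounds alone, the only earlier step, a 1.5-fold higher number from compound 1 to compound 2 (0.19 log units; within the scatter), concerned the aromatic substituent and separated nothing, so this chain position is the first place where a one-place change moves the number beyond the scatter, and it moves towards weaker inhibition. This reading rests on a single pair, and no available measurement bears on the reason for the rise.

Still open, from the compounds shown here alone, is whether a longer chain such as 3-chloropropyl would continue the rise, and whether an amine in place of the chloro group on the chain would give a similar number. Also open, going by these compounds, is whether the same chain change on the iodo-bearing compound 1 would give a step of similar size.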